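A few compounds are considered here, and "the series" means these few. Any claim that something is new, unique, unknown or untested is made for them only; others in the source may bear on it.

The account concerns two hydroxamic acids that have been measured for antiproliferative activity and a third one that awaits measurement. Compound 1 `O=C(CCCCCCN1C(=O)/C(=N\O)c2cc([N+](=O)[O-])ccc21)NO` was tested in a functional assay on ASPC1 cells (Homo sapiens) for antiproliferative activity, read by sulforhodamine B assay, with a stated time of 48 h (a lower number here means a stronger inhibitor, a higher number a weaker inhibitor), and in that test compound 1 gives 4680 nM. Compound 2 `CO/N=C1/C(=O)N(CCCCCCC(=O)NO)c2ccccc21` was measured in the same way, and in this assay compound 2 gives 1220 nM. Of the two numbers this is the lower one, and the gap to compound 1 lies beyond the usual scatter of repeated measurements, so compound 2 stands as the stronger inhibitor of the pair.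

Compound 3 `CO/N=C1/C(=O)N(CCCCCCC(=O)NO)c2ccc(F)cc21` differs from compound 2 in a single place: fluoro in place of hydrogen on an aromatic carbon. Within the data shown here, no measured pair in this set shows what such a change does to the read-out, so there is no step from which a direction could be taken. The writer expects only a modest shift, a 1.2-fold lower number from compound 2 to compound 3 (0.09 log units; within the scatter), one that would stay within the scatter rather than beyond it. On that basis compound 3 is expected to give about 1000 nM in this assay, with a range from 450 nM to 2400 nM.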

Compound 3, half-maximal inhibitory concentration: 970 nM
Estimate against measurement, compound 3: 1.0-fold (0.01 log units) above; the range from low to high includes it.
By their numbers in this assay, from the lowest: compounds 3 and 2 (each within the scatter of the next); then compound 1.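

In this assay, among these compounds, fluoro in place of hydrogen on an aromatic carbon gives the first reading of this change on the shared core, a 1.3-fold lower number from compound 2 to compound 3 (0.10 log units; within the scatter), so the two compounds cannot be told apart in this test. At this carbon of the six-membered aromatic ring, meta to a fused ring and para to a fused ring, the added fluorine atom therefore leaves no mark on the read-out that rises beyond the scatter, and this one step shows that the position accepts fluoro without a measurable loss of antiproliferative activity. No measurement at hand bears on why the read-out behaves this way.

As far as these compounds go, whether chloro, a methoxy group or an amine on the same aromatic carbon would also stay within the scatter of compound 2 remains open, as does the reading of fluoro on another carbon of that ring. The compounds shown also leave open how a longer chain leading to the hydroxamic acid, or a carboxylic acid in place of that hydroxamic acid, would read on the core of compound 3 in this assay.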